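A thiophene for chlorine on the aryl ring

The source may report more compounds than this note shows. Statements on the series, on what has been measured and on what is new or still open speak of the compounds shown alone.

Compound 1 `CO[C@@]12CCN(C)C[C@H]1[C@H](c1ccc(Cl)cc1)C(C#N)=C(N)O2` and compound 2 `CO[C@@]12CCN(Cc3ccccc3)C[C@H]1[C@H](c1ccc(Cl)cc1)C(C#N)=C(N)O2` share one core and have both been tested in a functional assay on trachea (Cavia porcellus); a higher number here means a weaker inhibitor, a lower number a stronger inhibitor. Compound 1 gives 10500 nM, and compound 2 gives 18500 nM. Compound 1 thus holds the number from which the other is reached by a 1.8-fold higher number from compound 1 to compound 2 (0.25 log units; within the scatter), a step that stays within the scatter, so the two compounds cannot be told apart on this evidence. Among the measured compounds shown here, that single comparison concerns the group on the ring nitrogen and is the only measured step available.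

Compound 3 `CO[C@@]12CCN(C)C[C@H]1[C@H](c1ccc(-c3cccs3)cc1)C(C#N)=C(N)O2` has not yet been measured. It differs from compound 1 by thiophen-2-yl in place of chloro on an aromatic carbon. For the measured compounds named here, no measured step touches this position: the one comparison at hand, a 1.8-fold higher number from compound 1 to compound 2 (0.25 log units; within the scatter), alters a different part of the molecule and leaves the number inside the scatter. The data therefore give no ground for expecting a shift in either direction beyond the scatter, only a wide uncertainty. Compound 3 is expected to give about 12000 nM, within a range of 3000 nM to 50000 nM. The step expected, a 1.1-fold higher number from compound 1 to compound 3 (0.06 log units; within the scatter), is accordingly close to flat.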

Compound 3, half-maximal inhibitory concentration: 13800 nM
For compound 3 the middle estimate is 1.2-fold (0.06 log units) below the measured one; low and high end bracket the measured number.
By their numbers in this assay, from the lowest: compounds 1, 3 and 2 (each within the scatter of the next).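

Among the compounds shown here, the first measured change at this aromatic carbon, thiophen-2-yl in place of chloro, gives in this assay a 1.3-fold higher number from compound 1 to compound 3 (0.12 log units; within the scatter) and so stays within the scatter. At this place, para to a large group, a single chlorine atom can therefore give way to a five-membered aromatic ring with one hetero atom, five heavy atoms in all and one hydrogen-bond acceptor, with no difference that this assay can resolve. This adds to the earlier comparison, which concerned only the group on the ring nitrogen, but no separate measurement bears on the result or offers an account of it.

The compounds shown leave open whether a group of another kind on this aromatic carbon, such as an amine or a carboxylic acid, would carry the number beyond the scatter. They also leave open whether thiophen-2-yl gives the same result when the methyl group on the ring nitrogen is replaced by the benzyl group of compound 2.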